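This account rests on a few compounds, and the source may have more. Where it says the series, first, only, none or still open, it means among the compounds named here.

Working notes on the series.

Three compounds have numbers in an ADME assay on Vero cells (Chlorocebus sabaeus) for cytotoxicity, read by MTT assay, with a stated time of 48 h; a lower number here means that less compound is tolerated, a higher number that more compound is tolerated. Compound 1 `C=C1CC[C@@H]2[C@](C)(CO)[C@H](O)CC[C@@]2(C)[C@@H]1C/C=C1/C(=O)OC[C@H]1Oc1cccnc1[N+](=O)[O-]` gives 37700 nM in this assay. Compound 2 `C=C1CC[C@@H]2[C@](C)(CO)[C@H](O)CC[C@@]2(C)[C@@H]1C/C=C1/C(=O)OC[C@@H]1Oc1c(Cl)cc(Cl)c2cccnc12` reaches only the assay limit in this assay, > 100000 nM, which is a limit and not a number. Compound 3 `C=C1CC[C@@H]2[C@](C)(CO)[C@H](O)CC[C@@]2(C)[C@@H]1C/C=C1/C(=O)OC[C@@H]1Oc1ccnc2ccccc12` gives 20700 nM in this assay. For the measured compounds named here, the one step measured within one change is an at least 4.8-fold lower number from compound 2 to compound 3 (0.68 log units; beyond the scatter), and the only evidence on it is the limit of > 100000 nM in this assay, at which 1 of the 3 values shown sits. Compound 3 thus stands at the lowest of the two numbers in this assay, with compound 1 within the scatter of it; the two values of compound 1 and compound 3 differ in two places and show no ordering.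

Compound 4 `C=C1CC[C@@H]2[C@](C)(CO)[C@H](O)CC[C@@]2(C)[C@@H]1C/C=C1/C(=O)OC[C@H]1Oc1ccnc2ccccc12` is the next in line. The change from compound 3 is the two compounds have the same atoms and bonds and differ only in configuration as drawn: 1 of 7 stereo elements differ; a stereocentre at a saturated ring carbon is drawn R in compound 3 and S in compound 4; the carbon in question is the one carrying the aryl ether oxygen on the lactone ring. Going by the values given here, no measured step follows a change of configuration alone, so no direction is read from the data. Compound 1 shares this drawn configuration with compound 4 and sits within the scatter of compound 3, which suggests no step beyond the scatter. Compound 4 is therefore expected to give 26000 nM in this assay, with a range of 10000 nM to 65000 nM, meaning an expected step of a 1.3-fold higher number from compound 3 to compound 4 (0.10 log units; within the scatter).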

Compound 4, half-maximal cytotoxic concentration: 22800 nM
Beside the measured number, compound 4's estimate is 1.1-fold (0.06 log units) above it, and the stated range covers the measured number.
By their numbers in this assay, from the lowest: compounds 3, 4 and 1 (each within the scatter of the next). At a limit, above all of these: compound 2.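

In this assay, the carbon carrying the aryl ether oxygen on the lactone ring now has a measured pair, and the step is a 1.1-fold higher number from compound 3 to compound 4 (0.04 log units; within the scatter), so R and S at this carbon do not separate the two quinolin-4-yl compounds, and this pair isolates that one carbon: the fact that compounds 3 and 4 differ only in the configuration as drawn With the S configuration held, quinolin-4-yl in place of 2-nitropyridin-3-yl gives a 1.7-fold lower number from compound 1 to compound 4 (0.22 log units; within the scatter), so this change of aryl group also stays inside the scatter. The only step beyond the scatter remains an at least 4.8-fold lower number from compound 2 to compound 3 (0.68 log units; beyond the scatter), and it rests on a limit: the limit of > 100000 nM in this assay, at which 1 of the 4 values shown sits.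

The compounds shown leave open whether the configuration at this carbon counts for as little with 5,7-dichloroquinolin-8-yl on the oxygen as with quinolin-4-yl. They also leave open what an amine or a carboxylic acid on the aryl group would do to the number in this assay.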